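Dichlorophenyl in place of phenyl on the shared core

The compounds below may be only part of what the source reports. "The series", "measured", "known", "first", "only" and "open" are said of these compounds alone.

Compound 1, `O=C1COc2ccc(-c3nn(-c4ccc(Cl)cc4)cc3-c3ccccc3)cc2N1`: 108%
Compound 2, `O=C1COc2ccc(-c3[nH]c(-c4ccccc4)nc3-c3ccccc3)cc2N1`: 105%

In a functional assay on MV4-11 cells (Homo sapiens) for cytotoxicity, read by colorimetric assay and MTT assay, with a stated time of 3 days, tested at 1 uM (a higher number here means a weaker effect of the compound at the concentration tested, a lower number a stronger effect), compound 2 gives 105%, and compound 1 gives 108%; the two numbers lie within the usual scatter of each other, so neither compound stands apart. Compound 3, `O=C1COc2ccc(-c3[nH]c(-c4ccc(Cl)cc4Cl)nc3-c3ccccc3)cc2N1`, is not yet measured. It differs from compound 2 in one place: 2,4-dichlorophenyl in place of phenyl on an aromatic carbon. Among the compounds with values here, no measured pair shows what such a change does here, so the step from compound 2 to compound 3 in this assay is expected to be small, at most a modest fall, with a number 5 percentage points lower from compound 2 to compound 3 (within the scatter) as the estimate. Compound 3 is therefore expected to give about 100%, between 78% and 112%.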

Compound 3, a percentage reported as activity, at one concentration (the size of the read-out at that concentration, not a potency): 109%
Estimate against measurement, compound 3: 9 percentage points below; the range from low to high includes it.
By their numbers in this assay, from the lowest: compounds 2, 1 and 3 (each within the scatter of the next).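

In this assay putting 2,4-dichlorophenyl in place of phenyl, on the aromatic carbon between two ring nitrogen atoms, gives a number 4 percentage points higher from compound 2 to compound 3 (within the scatter) and so shows that adding these two chlorine atoms at this position does not shift the read-out beyond the scatter at this single concentration. Nothing measured here offers an explanation for this result. Still open, as far as these compounds go, is whether an amine or a carboxylic acid on that phenyl ring, in place of the chlorine atoms, would give a number clearly apart from compound 2.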